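The source may report more compounds than this note shows. Statements on the series, on what has been measured and on what is new or still open speak of the compounds shown alone.

Three compounds have values so far in an ADME assay on microsomes from liver (Homo sapiens) for metabolic stability (on this read-out higher numbers stand for a longer-lived compound and lower numbers for a shorter-lived compound), and stand as follows:

- Compound 1 `CC#C[C@@H](Cc1nnn[nH]1)c1ccc(OCc2ccc3scc(-c4cc(OCCOC)ccc4C)c3c2)cc1` gives 0.867 h
- Compound 2 `CC#C[C@@H](Cc1nnn[nH]1)c1ccc(OCc2cc(Cl)c3scc(-c4ccccc4C)c3c2)cc1` gives 0.217 h
- Compound 3 `CC#C[C@@H](Cc1nnn[nH]1)c1ccc(OCc2ccc3sc(Cl)c(-c4ccccc4C)c3c2)cc1` gives 0.175 h

Compound 2, at 0.217 h in this set, lies within the scatter of compound 3, at 0.175 h on the same read-out. Compound 1, at 0.867 h here, stands higher than compound 2 by a margin beyond the scatter.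

Compound 4 `CC#C[C@@H](Cc1nnn[nH]1)c1ccc(OCc2cc(C)c3scc(-c4ccccc4C)c3c2)cc1` has not yet been measured. It departs from compound 2 by one change, (methyl in place of chloro on an aromatic carbon), with methyl in place of chloro on an aromatic carbon. For the measured compounds named here, no pair of measured compounds differs in one place only, so the data give no direct guide to this swap. The expectation therefore rests loosely on compound 2 at 0.217 h and compound 3 at 0.175 h, two structurally different compounds whose values sit within the scatter of each other. No step beyond the scatter is expected in this assay, and no clear direction can be argued from so few compounds. The estimated step is a 1.1-fold lower number from compound 2 to compound 4 (0.04 log units; within the scatter), which would be too small to read as a real change. For compound 4 the estimated half-life is 0.2 h, with an expected range from 0.1 h to 0.4 h.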

Compound 4, half-life: < 0.0667 h
Compound 4: no number, only a limit; the forecaster's own chance of this, stated with the estimate: 3%; middle value at least 2.9-fold (0.47 log units) away from the limit.
By their numbers in this assay, from the lowest: compounds 3 and 2 (each within the scatter of the next); then compound 1. At a limit, below all of these: compound 4.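

In this assay, for the compounds shown here, the swap of chloro for methyl on this aromatic carbon, ortho to a fused ring and meta to a large group, gives the first comparison in the set between compounds that differ in one place only, and it comes out as an at least 3.2-fold lower number from compound 2 to compound 4 (0.51 log units; beyond the scatter). Exchanging one heavy atom for another, with no change in hydrogen-bond donors, acceptors or net charge, is therefore enough to separate the two compounds beyond the scatter, so this position is not indifferent to the group it carries. Compound 4 gives < 0.0667 h, which is a limit of the assay and not a number, so the step fixes a direction and only a minimum size: the limit of < 0.0667 h in this assay, at which 1 of the 4 values shown sits.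

Going by these compounds, it remains open whether chloro lengthens the half-life or methyl shortens it, since the comparison has only these two groups, and how hydrogen, fluoro, methoxy or a nitrile would stand at this position. Also open, on these data alone, is whether the same swap would give a step of similar size on the core of compound 1, with its methoxyethoxy chain.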